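A few compounds are considered here, and "the series" means these few. Any claim that something is new, unique, unknown or untested is made for them only; others in the source may bear on it.

Measured so far in a functional assay on KG-1 cells (Homo sapiens) for inhibition, read by MTT assay, with a stated time of 48 h; on this read-out lower numbers stand for stronger inhibition and higher numbers for weaker inhibition:
- Compound 1 `O=C(CCCOc1no[n+]([O-])c1S(=O)(=O)c1ccccc1)NO`: 1480 nM
- Compound 2 `O=C(CCCCOc1no[n+]([O-])c1S(=O)(=O)c1ccccc1)NO`: 1910 nM

Among the measured compounds shown here, with only two numbers available, compound 2 stands within the usual scatter of compound 1, so the two cannot be ranked. The next compound, compound 3 `O=C(CCCCCCOc1no[n+]([O-])c1S(=O)(=O)c1ccccc1)NO`, keeps the shared core and lengthens the chain that carries the hydroxycarbamoyl group. It has 2-(hydroxycarbamoyl)ethyl in place of hydroxycarbamoyl on a saturated chain carbon, four bonds along the chain from an oxygen on an aromatic ring.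

For the measured compounds named here, the one measured step that bears on this is a 1.3-fold higher number from compound 1 to compound 2 (0.11 log units; within the scatter). It is also a lengthening at the same end of the chain, and it stays within the scatter. A single small step is thin evidence, however, and the new extension is longer than that one, so a surprise in either direction remains possible.

In this assay, the estimated change is a 1.5-fold lower number from compound 2 to compound 3 (0.17 log units; within the scatter), which is not expected to be a clear step beyond the scatter. For compound 3 the expected value is 1300 nM, with an estimated range from 400 nM to 3500 nM.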

Compound 3, half-maximal inhibitory concentration: 4270 nM
Compound 3: middle estimate off by 3.3-fold (0.52 log units), on the low side, outside the stated range (above it).
By their numbers in this assay, from the lowest: compounds 1 and 2 (each within the scatter of the next); then compound 3.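

Lengthening the chain that carries the hydroxycarbamoyl group gave no readable change between compound 1 and compound 2, but a further extension does weaken inhibition in this assay: 2-(hydroxycarbamoyl)ethyl in place of hydroxycarbamoyl gives a 2.2-fold higher number from compound 2 to compound 3 (0.35 log units; beyond the scatter), and 3-(hydroxycarbamoyl)propyl in place of hydroxycarbamoyl gives a 2.9-fold higher number from compound 1 to compound 3 (0.46 log units; beyond the scatter). Both steps are modest but lie beyond the scatter, so compound 3, with the longest chain, is the weakest of these three, and the effect of chain length is uneven: the first extension stays within the scatter, while the next one does not. No measurement at hand explains why the longer chain does worse.

These compounds leave open whether inhibition keeps falling with a still longer chain, and whether a chain shorter than that of compound 1 would give stronger or weaker inhibition. They also cannot show whether the hydroxycarbamoyl group itself is needed at the chain end, which a carboxylic acid or a primary amide in its place would test.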